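The source may hold more compounds than are shown below. What is called first, only, known or untested is meant among the compounds shown, and "the series" means these compounds.

Compound 1 `CC1CC/C(=N\Nc2ccccc2Br)c2ncc(C(=O)O)c(=O)n21` sits at a limit in a functional assay on the whole organism for inhibition, with Rattus norvegicus as the target; a higher number here means that more compound is needed for the effect, a lower number that less compound is needed: compound 1 gives > 320 umol/kg, a limit of the assay rather than a number (the limit of > 320 umol/kg in this assay, at which 1 of the 2 values shown sits). Compound 2 `COc1ccc(N/N=C2\CCC(C)n3c2ncc(C(=O)O)c3=O)cc1` gives 7.6 umol/kg in this assay. Among the compounds with values here, the only measured step, an at least 42-fold lower number from compound 1 to compound 2 (1.62 log units; beyond the scatter), alters the group on the amine nitrogen and does not touch the change to compound 3 `CC1CC/C(=N\Nc2ccccc2C(F)(F)F)c2ncc(C(=O)O)c(=O)n21`, which differs from compound 1 by trifluoromethyl in place of bromo on an aromatic carbon. Within the data shown here, no measured step bears on this change, so no step beyond the scatter is expected in this assay, and a limit may again be reported. Compound 3 is expected at 400 umol/kg, between 150 umol/kg and 1200 umol/kg, an expected step that the limit leaves unreadable from compound 1 to compound 3.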

Compound 3, dose for 50% inhibition: > 1000 umol/kg
Compound 3 gave a limit, no number; the forecaster's own chance of this, stated with the estimate: 70%; middle value at least 2.5-fold (0.39 log units) from the limit.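

Within the data shown here, compound 1 and compound 3 both give limits rather than numbers in this assay, so no step between them can be read. From the compounds shown here alone, whether trifluoromethyl in place of bromo changes the dose needed remains open.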